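This account rests on a few compounds, and the source may have more. Where it says the series, first, only, none or still open, it means among the compounds named here.

Compound 1 `O=C(c1ccccc1)n1c(-c2cn(-c3ccccc3)nc2-c2ccc(C(F)(F)F)cc2)nc2ccccc21` is the starting point of this step. Going by the values given here, in an ADME assay on HEK-293T cells (Homo sapiens) for cytotoxicity, read by MTT assay, with a stated time of 24 h (a lower number here means that less compound is tolerated, a higher number that more compound is tolerated), compound 1 gives 168000 nM, the lowest of the three numbers measured so far, though its two companions sit close by. Compound 2 `Cc1ccc(-c2nn(-c3ccccc3)cc2-c2nc3ccccc3n2C(=O)c2ccccc2)cc1` gives 204000 nM, and compound 3 `O=C(c1ccccc1)n1c(-c2cn(-c3ccccc3)nc2-c2ccc(F)cc2)nc2ccccc21` gives 180000 nM. The measured steps are all small: a 1.2-fold higher number from compound 1 to compound 2 (0.08 log units; within the scatter), a 1.1-fold higher number from compound 1 to compound 3 (0.03 log units; within the scatter) and a 1.1-fold lower number from compound 2 to compound 3 (0.05 log units; within the scatter). Each of these swaps one group on the same aromatic ring of the shared core, and none moves the number beyond the scatter.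

Compound 4 `Cc1ccccc1C(=O)n1c(-c2cn(-c3ccccc3)nc2-c2ccc(C(F)(F)F)cc2)nc2ccccc21` differs from compound 1 in one place: methyl in place of hydrogen on an aromatic carbon. Among the compounds with values here, none of the measured steps touches the benzoyl part of the molecule, so there is no direct precedent for this change. What the data do show is that three single-group swaps elsewhere in the core left the number essentially unchanged. The expected step is therefore a 1.0-fold higher number from compound 1 to compound 4 (0.01 log units; within the scatter), which is nothing beyond the scatter. Compound 4 is expected to give 170000 nM, with a plausible range from 85000 nM to 340000 nM.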

Compound 4, half-maximal cytotoxic concentration: 179000 nM
Estimate against measurement, compound 4: 1.1-fold (0.02 log units) below, and the stated range covers the measured number.
By their numbers in this assay, from the lowest: compounds 1, 4, 3 and 2 (each within the scatter of the next).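

The earlier steps shown here all swapped a group on one aromatic ring of the shared core, so compound 4 gives the first reading from the benzoyl part of the molecule. In this assay there is a 1.1-fold higher number from compound 1 to compound 4 (0.03 log units; within the scatter), so adding a methyl to this ring, ortho to a large group, changes the number no more than the earlier swaps did, and tolerance of a small addition here extends to a second region of the molecule. Nothing measured here offers an explanation for this result.

Still open, as far as these compounds go, is whether an amine, a carboxylic acid or a longer chain at this place would leave the number just as steady. From the compounds shown here alone, it is also open whether a methyl elsewhere on this ring would behave the same way.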